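The compounds below may be only part of what the source reports. "The series", "measured", "known", "first", "only" and "open" are said of these compounds alone.

Measured in an assay on membranes from brain for displacement of a labelled ligand from Sigma non-opioid intracellular receptor 1 (Cavia porcellus), read by scintillation counting, with a stated time of 120 min; on this read-out lower numbers stand for stronger inhibition and higher numbers for weaker inhibition:
Compound 1 `c1ccc(CCCCNC2CCc3ccsc3CC2)cc1` gives 62 nM.
Compound 2 `CN(Cc1ccccc1)C1CCc2ccsc2CC1` gives 49 nM.
Compound 3 `CCN(Cc1ccccc1)C1CCc2ccsc2CC1` gives 60 nM.

Compound 1 has the highest of the three numbers, but its gaps to compound 3 and to compound 2 both lie within the usual scatter, so the three cannot be ranked. Compound 4 `CCN(CCCCc1ccccc1)C1CCc2ccsc2CC1` differs from compound 1 by ethyl in place of hydrogen on an amine nitrogen. Going by the values given here, the only measured step that bears on this is a 1.2-fold higher number from compound 2 to compound 3 (0.09 log units; within the scatter), where the group on the amine nitrogen was also lengthened, from methyl to ethyl, without moving the number beyond the scatter. Compounds 2 and 3, which already carry a second group on that nitrogen, sit within the scatter of compound 1. Compound 4 is therefore expected to show no step beyond the scatter in this assay, with an estimated 55 nM (range 25 nM to 130 nM), that is a 1.1-fold lower number from compound 1 to compound 4 (0.05 log units; within the scatter).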

Compound 4, inhibition constant: 12 nM
Beside the measured number, compound 4's estimate is 4.6-fold (0.66 log units) above it, outside the stated range (below it).
By their numbers in this assay, from the lowest: compound 4; then compounds 2, 3 and 1 (each within the scatter of the next).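

Putting ethyl in place of hydrogen on the amine nitrogen gives a 5.2-fold lower number from compound 1 to compound 4 (0.71 log units; beyond the scatter) in this assay. Going by these compounds alone, the earlier step on this nitrogen, a 1.2-fold higher number from compound 2 to compound 3 (0.09 log units; within the scatter), stayed small, so this is the first sign that a change at this position can move the number beyond the scatter. Nothing available explains this gain.

Still open, on these data alone, is how methyl, propyl or a longer chain on this nitrogen would compare with ethyl. A ring such as cyclopropyl in that place also remains untested in the compounds shown here.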